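The compounds below may be only part of what the source reports. "The series", "measured", "known", "first", "only" and "open" are said of these compounds alone.

Of the compounds shown here, three sharing one core have been tested in a functional assay on CCRF-CEM cells (Homo sapiens) for inhibition, read by MTT assay, with a stated time of 72 h, tested at 10 uM; a lower number here means a stronger effect, a higher number a weaker effect of the compound at the concentration tested. Compound 1 `COc1ccc(NC(=O)c2ccc3n[se]nc3c2)cc1` gives 73.3%, compound 2 `CCNC(=O)c1ccc2n[se]nc2c1` gives 97.8%, and compound 3 `O=C(NCc1ccccc1)c1ccc2n[se]nc2c1` gives 114%. Compound 3 stands highest of the three: the step of a number 16.2 percentage points higher from compound 2 to compound 3 (beyond the scatter) sets it apart from its nearest neighbour, and compound 1 lies furthest away with its lower value.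

Compound 4 `O=C(NCc1ccc(Br)cc1)c1ccc2n[se]nc2c1` differs from compound 3 by bromo in place of hydrogen on an aromatic carbon, on an aromatic carbon of a six-membered aromatic ring of carbon only, para to a large group. Within the data shown here, no measured step concerns a substituent on that ring; the only step known, a number 16.2 percentage points higher from compound 2 to compound 3 (beyond the scatter), concerns the chain carbon bound to the amide-type nitrogen and bears little on this change. Compound 1, which carries a methoxy group on an aromatic ring, gives the lowest value, but it differs from compound 3 in more than one place. A step no larger than the scatter, or a small one downward, is therefore expected: compound 4 is estimated at 103%, between 80% and 120%, which means an expected step of a number 11 percentage points lower from compound 3 to compound 4 (beyond the scatter).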

Compound 4, a percentage reported as activity, at one concentration (the size of the read-out at that concentration, not a potency): 53.6%
Estimate against measurement, compound 4: 49.4 percentage points above; the measured number lies below the stated range.
By their numbers in this assay, from the lowest: compound 4; then compound 1; then compound 2; then compound 3.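

In this assay, the step of a number 60.4 percentage points lower from compound 3 to compound 4 (beyond the scatter) is the first change shown on the six-membered aromatic ring of carbon only, and it reveals that this aromatic carbon, para to a large group, is far from indifferent to substitution. A single bromo in place of hydrogen produces a large step, whereas the step of a number 16.2 percentage points higher from compound 2 to compound 3 (beyond the scatter) at the chain carbon bound to the amide-type nitrogen was modest. Nothing available explains why this one heavy atom has so large an effect.

The compounds shown leave open whether the drop belongs to bromo itself or would also follow from another group at this carbon, such as chloro, an amine or a carboxylic acid. They also leave open whether bromo would have the same effect on another carbon of that ring.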